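A few compounds are considered here, and "the series" means these few. Any claim that something is new, unique, unknown or untested is made for them only; others in the source may bear on it.

In a functional assay on J774 cells (Mus musculus) for cytotoxicity, read by resazurin assay; on this read-out lower numbers stand for stronger inhibition and higher numbers for weaker inhibition:
- compound 1 `OCCCCCC(O)c1ccc(-c2ccc(F)cc2)cc1`: 18000 nM
- compound 2 `OCCCCCC(O)c1ccc(-c2ccc(O)cc2)cc1`: 15000 nM
- compound 3 `OCCCCCC(O)c1ccc(-c2cccc(Cl)c2)cc1`: > 100000 nM (a limit of the assay, not a number)

Compound 3 stands only at a limit, with no number: > 100000 nM.

The next compound is compound 4 `OCCCCCC(O)c1ccc(-c2ccc(Cl)cc2)cc1`, with 4-chlorophenyl in place of 3-chlorophenyl on an aromatic carbon. Compound 4 places its chlorine as compound 1 places its fluorine and compound 2 its hydroxy.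

Within the data shown here, two measured steps bear on this change: an at least 5.5-fold higher number from compound 1 to compound 3 (0.74 log units; beyond the scatter) and an at least 6.6-fold higher number from compound 2 to compound 3 (0.82 log units; beyond the scatter). Both lie beyond the scatter and are at least modest. A third, a 1.2-fold lower number from compound 1 to compound 2 (0.08 log units; within the scatter), stays within the scatter. If compound 4 follows compound 1 and compound 2, a step to a lower number, beyond the scatter, is expected in this assay. The expected step is an at least 6.2-fold lower number from compound 3 to compound 4 (0.79 log units; beyond the scatter). Only a lower bound on its size can be expected, given the limit.

For compound 4 the estimate is 16000 nM, with an expected range of 6000 nM to 45000 nM.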

Compound 4, half-maximal inhibitory concentration: 17000 nM
The estimate for compound 4 lay 1.1-fold (0.03 log units) below the measured number; low and high end bracket the measured number.
By their numbers in this assay, from the lowest: compounds 2, 4 and 1 (each within the scatter of the next). At a limit, above all of these: compound 3.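

In this assay, 4-chlorophenyl in place of 3-chlorophenyl, with the same atoms joined differently, gives an at least 5.8-fold lower number from compound 3 to compound 4 (0.76 log units; beyond the scatter), so the placement of the chlorine on this ring decides the read-out here, not the presence of chloro as such. Chloro in compound 4 also sits level with the fluoro and hydroxy groups, with a 1.1-fold higher number from compound 2 to compound 4 (0.05 log units; within the scatter) and a 1.1-fold lower number from compound 1 to compound 4 (0.02 log units; within the scatter), both within the scatter, so these three groups are not told apart in this series when they occupy the same place. Compound 3 stands at a limit, so the step from it gives only a lower bound on the size: the limit of > 100000 nM in this assay, at which 1 of the 4 values shown sits.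

3-Chlorophenyl is the only ring of its kind shown, so it remains open whether the higher number belongs to chloro alone or would also follow other groups at that place. From the compounds shown here alone, how an amine or a carboxylic acid in place of the chloro of compound 4 would read also remains open.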